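The compounds below may be only part of what the source reports. "The series", "measured", "known", "first", "only" and "open" are said of these compounds alone.

Measured compounds:
- compound 1 `O=C(Nc1cccc(-n2cc(-c3ccncc3)c(-c3cc(O)cc(Cl)c3)n2)c1)Nc1ccc(Cl)c(Cl)c1`: 95%
- compound 2 `COc1cc(Cl)cc(-c2nn(-c3cccc(NC(=O)Nc4ccc(Cl)c(C(F)(F)F)c4)c3)cc2-c2ccncc2)c1`: 87%
- compound 3 `COc1cc(Cl)cc(-c2nn(-c3cccc(NC(=O)Nc4ccc(Cl)c(Cl)c4)c3)cc2-c2ccncc2)c1`: 102%

In a functional assay on IGROV-1 cells (Homo sapiens) for inhibition, read by sulforhodamine B assay, with a stated time of 48 h, tested at 1 uM (a higher number here means a weaker effect of the compound at the concentration tested, a lower number a stronger effect), compound 3 gives the highest of the three numbers. The nearest is compound 1, with a number 7 percentage points higher from compound 1 to compound 3 (within the scatter); the furthest is compound 2, with a number 15 percentage points higher from compound 2 to compound 3 (beyond the scatter). Neither step marks compound 3 as set apart from both others.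

Compound 4 `COc1cc(Cl)cc(-c2nn(-c3cccc(NC(=O)c4cccc(C(F)(F)F)c4)c3)cc2-c2ccncc2)c1` differs from compound 3 in one place: 3-(trifluoromethyl)phenyl in place of (3,4-dichlorophenyl)amino on a carbonyl carbon. Cut one bond further out, the same difference reads (3,4-dichlorophenyl)carbamoyl to (3-(trifluoromethyl)phenyl)carbonyl. Going by the values given here, no measured step covers the loss of the amino link on the carbonyl carbon. Among the compounds with values here, the only step that touches the incoming group is that from compound 2 to compound 3, where trifluoromethyl on the distal ring went with the lower number; it was modest. All three measured numbers sit high in this assay, so compound 4 is expected to stay near them, with at most a small downward step, a number 10 percentage points lower from compound 3 to compound 4 (within the scatter). The estimate for compound 4 in this assay is 92%, expected between 75% and 106%.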

Compound 4, a percentage reported as activity, at one concentration (the size of the read-out at that concentration, not a potency): 94%
Compound 4: the middle estimate sits 2 percentage points below what was measured; the range from low to high includes it.
By their numbers in this assay, from the lowest: compounds 2, 4, 1 and 3 (each within the scatter of the next, the first and the last beyond it).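

In this assay, 3-(trifluoromethyl)phenyl in place of (3,4-dichlorophenyl)amino on the carbonyl carbon gives a number 8 percentage points lower from compound 3 to compound 4 (within the scatter), and the same group in place of (4-chloro-3-(trifluoromethyl)phenyl)amino gives a number 7 percentage points higher from compound 2 to compound 4 (within the scatter). Going by these compounds alone, removing the amino link and its hydrogen-bond donor at this carbonyl carbon therefore leaves the number within the scatter of both neighbours, which the earlier steps could not show, as they changed only substituents on aromatic rings or the methyl on an oxygen. No independent data bear on this result.

All four numbers sit high at the single concentration tested, so this read-out may not separate these compounds well. From the compounds shown here alone, it remains open whether a piperazine, a carboxylic acid or a short alkyl chain on this carbonyl carbon would give a clearly lower number in this assay.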